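The source may hold more compounds than are shown below. What is called first, only, known or untested is meant among the compounds shown, and "the series" means these compounds.

Compound 3 `Cc1cc(Cl)ccc1NC(=O)Nc1nc(Nc2ccccc2)cc(Sc2c[nH]c3ccccc23)n1` stands at a limit in a functional assay on A549 cells (Homo sapiens) for inhibition, with a stated time of 72 h; a higher number here means a weaker inhibitor, a lower number a stronger inhibitor: its result is given only as > 50000 nM, which means the assay reached its top concentration without a usable number; this limit is the limit of > 50000 nM in this assay, at which 1 of the 3 values shown sits. Compound 3 is therefore the compound of the three measured here whose activity is least defined.

Compound 4 `Cc1cc(Cl)ccc1NC(=O)Nc1nc(Sc2c[nH]c3ccccc23)cc(N2CCCC2)n1` differs from compound 3 in one place: pyrrolidin-1-yl in place of anilino on an aromatic carbon. Among the measured compounds shown here, none of the measured steps makes this same change, so the size of the move from compound 3 to compound 4 cannot be read directly from the data. Compound 1 `O=C(Nc1ccc(Cl)cc1)Nc1nc(Sc2c[nH]c3ccccc23)cc(N2CCCC2)n1` and compound 2 `O=C(Nc1ccccc1)Nc1nc(Sc2c[nH]c3ccccc23)cc(N2CCCC2)n1` do carry the pyrrolidin-1-yl group that enters in compound 4. In this assay compound 1 gives 6410 nM. In this assay compound 2 gives 21200 nM. For the measured compounds named here, the one measured step, a 3.3-fold higher number from compound 1 to compound 2 (0.52 log units; beyond the scatter), shows a modest loss when chloro is replaced by hydrogen. Compound 4 keeps the chloro of compound 1 and adds a methyl on the same ring, so its expected value is placed near compound 1, with a wide range since compound 3 only sets a limit. For compound 4 the estimate is 8000 nM, between 2000 nM and 40000 nM. The expected step is therefore an at least 6.2-fold lower number from compound 3 to compound 4 (0.79 log units; beyond the scatter).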

Compound 4, half-maximal inhibitory concentration: 8930 nM
Estimate against measurement, compound 4: 1.1-fold (0.05 log units) below; the measured number falls inside the stated range.
By their numbers in this assay, from the lowest: compounds 1 and 4 (each within the scatter of the next); then compound 2. At a limit, above all of these: compound 3.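

At this position, next to the ring nitrogen, putting pyrrolidin-1-yl in place of anilino gives a readable result in this assay, with an at least 5.5-fold lower number from compound 3 to compound 4 (0.74 log units; beyond the scatter). The result for compound 3 is a limit and not a number: the limit of > 50000 nM in this assay, at which 1 of the 4 values shown sits. With pyrrolidin-1-yl in place, the 4-chloro-2-methylphenyl group in place of phenyl gives a 2.4-fold lower number from compound 2 to compound 4 (0.38 log units; beyond the scatter), while the added methyl gives a 1.4-fold higher number from compound 1 to compound 4 (0.14 log units; within the scatter), so the extra methyl makes no change that can be told from the scatter.

As far as these compounds go, the true size of the step from anilino to pyrrolidin-1-yl stays open, since only one side of it is a number, and so does the question of whether the ring of pyrrolidin-1-yl matters at all or whether an open-chain amine such as dimethylamino, or a six-membered ring such as morpholine, would serve equally well at this position. Also open, from the compounds shown here alone, is whether the 4-chloro-2-methylphenyl group would give a readable result alongside anilino if the chloro were exchanged for another group, such as methoxy or a nitrile.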